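Swapping Fluoro for Methyl: An Expected Gain in Binding

The source may report more compounds than this note shows. Statements on the series, on what has been measured and on what is new or still open speak of the compounds shown alone.

Compound 1 `Cc1ccc2ncc(S(=O)(=O)c3cccc(F)c3)c(N3CCC(C)CC3)c2c1` gives 94% in an assay on isolated protein for displacement of a labelled ligand from metabotropic glutamate receptor 5 (Homo sapiens), with a stated time of 60 min, tested at 1 uM; on this read-out higher numbers stand for more inhibition at the one concentration tested (going by the name of the read-out) and lower numbers for less inhibition.
Compound 2 `CC1CCN(c2c(S(=O)(=O)c3cccc(F)c3)cnc3ccc(F)cc23)CC1` gives 76%.
Compound 3 `CC1CCN(c2c(S(=O)(=O)c3ccc(C#N)cc3)cnc3ccc(F)cc23)CC1` gives 75%.

Compounds 2 and 3 share a core and differ only in the group on the sulfonyl sulfur, (4-cyanophenyl in place of 3-fluorophenyl on a sulfonyl sulfur); that difference made a number 1 percentage points lower from compound 2 to compound 3 (within the scatter), so the two cores behave alike here. Compound 1 differs from compound 2 by a single change, (methyl in place of fluoro on an aromatic carbon), and that change made a number 18 percentage points higher from compound 2 to compound 1 (beyond the scatter).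

Compound 4 `Cc1ccc2ncc(S(=O)(=O)c3ccc(C#N)cc3)c(N3CCC(C)CC3)c2c1` has not yet been measured. For the measured compounds named here, it arises from compound 3 by methyl in place of fluoro on an aromatic carbon, which is the same change, at the very same place, as the one already seen between compounds 2 and 1; only the group on the sulfonyl sulfur differs between the two pairs. Because the earlier step gave a number 18 percentage points higher from compound 2 to compound 1 (beyond the scatter), a step of similar size is expected here, namely a number 14 percentage points higher from compound 3 to compound 4 (beyond the scatter), kept slightly smaller since the read-out cannot rise far above the value of compound 1. Compound 4 is therefore estimated at 89%, with a likely range from 78% to 97%.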

Compound 4, a percentage reported as inhibition, at one concentration (the size of the read-out at that concentration, not a potency): 55%
Beside the measured number, compound 4's estimate is 34 percentage points above it, and the stated range ends above it.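

Methyl in place of fluoro gave a number 20 percentage points lower from compound 3 to compound 4 (beyond the scatter), the opposite direction to the earlier step, so in this assay this change does not carry over from one core to the other: the same change on two cores in this assay, a number 18 percentage points higher (beyond the scatter) from compound 2 to compound 1 and a number 20 percentage points lower (beyond the scatter) from compound 3 to compound 4, 38 percentage points apart, beyond the scatter of two such steps. The swap on the sulfonyl sulfur also depends on its surroundings, since with the methyl in place it gave a number 39 percentage points lower from compound 1 to compound 4 (beyond the scatter), whereas with the fluoro in place its step lay within the scatter: the same change on two cores in this assay, a number 1 percentage points lower (within the scatter) from compound 2 to compound 3 and a number 39 percentage points lower (beyond the scatter) from compound 1 to compound 4, 38 percentage points apart, beyond the scatter of two such steps. The two changes therefore do not add up independently across these four compounds, but this rests on a single set of four and does not show what lies behind the reversal or whether it would hold for other groups.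

The compounds shown leave open how other groups on that aromatic carbon, such as chloro or methoxy, would behave with each group on the sulfonyl sulfur. They also leave open whether an unsubstituted phenyl on the sulfonyl sulfur would follow the 3-fluorophenyl or the 4-cyanophenyl compounds.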